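Chloro in place of hydrogen: working notes on a small series

The compounds below may be only part of what the source reports. "The series", "measured", "known", "first", "only" and "open" are said of these compounds alone.

Values in a functional assay on the whole organism for inhibition, with Rattus norvegicus as the target; on this read-out lower numbers stand for stronger inhibition and higher numbers for weaker inhibition
- compound 1 `O=C1ON=C(c2cccs2)/C1=C/c1ccccc1O` gives 5700 nM
- compound 2 `O=C1ON=C(c2cccs2)/C1=C/c1ccccc1` gives 4400 nM
- compound 3 `O=C1ON=C(c2cccs2)/C1=C/c1ccc(Cl)cc1` has not yet been measured

In this assay compound 2 gives 4400 nM and stands within the scatter of compound 1, so the two cannot be ranked. The change under review is chloro in place of hydrogen on an aromatic carbon, here chloro in place of hydrogen on an aromatic carbon, para to a large group. Among the compounds with values here, only one measured step bears on it, and only indirectly: hydrogen in place of hydroxy on an aromatic carbon, which gives a 1.3-fold lower number from compound 1 to compound 2 (0.11 log units; within the scatter). Within the data shown here, that step involves a different group, and no chloro compound has been measured, so the range is kept wide. Among the measured compounds shown here, with a 1.3-fold lower number from compound 1 to compound 2 (0.11 log units; within the scatter) as the sole guide, no step beyond the scatter is expected in this assay. The expected step is a 1.3-fold lower number from compound 2 to compound 3 (0.10 log units; within the scatter). For compound 3 the estimate is 3500 nM, with an expected range from 1500 nM to 8500 nM.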

Compound 3, half-maximal inhibitory concentration: 6200 nM
Beside the measured number, compound 3's estimate is 1.8-fold (0.25 log units) below it; measured number inside the range.
By their numbers in this assay, from the lowest: compounds 2, 1 and 3 (each within the scatter of the next).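

In this assay, within the data shown here, chloro in place of hydrogen on an aromatic carbon, para to a large group, gives a 1.4-fold higher number from compound 2 to compound 3 (0.15 log units; within the scatter), so at this position the entering chloro brings no step that can be told from the scatter. The earlier step, a 1.3-fold lower number from compound 1 to compound 2 (0.11 log units; within the scatter), bore only on hydroxy, which leaves this pair as the sole direct reading on chloro in the compounds shown and extends the set of small changes on this ring that stay within the scatter to two. No measurement is at hand that would explain this result.

Going by these compounds, whether a larger or charged group at this position, such as an amine or a carboxylic acid, would give a step beyond the scatter remains open. So does the outcome of replacing chloro with a longer chain, such as butoxy, on the same carbon.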